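The compounds below may be only part of what the source reports. "The series", "measured", "known", "first", "only" and "open" are said of these compounds alone.

Compound 1, with the structure `COc1cc(NC(=O)C(C)(O)C(F)(F)F)ccc1S(=O)(=O)c1ccccc1`, was tested in a functional assay (Cavia porcellus) with sulfonylurea receptors; K-ATP channels (Homo sapiens) as the target (a lower number here means a stronger inhibitor, a higher number a weaker inhibitor), and gave 5900 nM. Going by the values given here, of the two numbers measured so far, this is the highest one. Among the compounds with values here, the only other compound measured is compound 2, built as `COc1ccccc1S(=O)(=O)c1ccc(NC(=O)C(C)(O)C(F)(F)F)cc1`, which in this assay gave 1600 nM; its number is lower than that of compound 1, and the gap between the two lies beyond the usual scatter. Within the data shown here, the two structures differ in more than one place, so no single step between them can be drawn.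

Compound 3, built as `CC(O)(C(=O)Nc1ccc(S(=O)(=O)c2ccccc2)c(C(=O)O)c1)C(F)(F)F`, is still to be measured. It is derived from compound 1 by one change: carboxy in place of methoxy on an aromatic carbon. Among the measured compounds shown here, no pair of measured compounds shows this kind of exchange, so there is no direct guide to its effect. With nothing to lean on, the step of a 1.3-fold lower number from compound 1 to compound 3 (0.12 log units; within the scatter) is expected to be modest and to stay close to the scatter, with no firm direction. The value for compound 3 in this assay is therefore estimated at 4500 nM, within a range from 1200 nM to 18000 nM.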

Compound 3, half-maximal inhibitory concentration: > 30000 nM
Compound 3 ended at the assay's limit; the forecaster's own chance of this, stated with the estimate: 10%; at least 6.6-fold (0.82 log units) between middle value and limit.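

On the aromatic carbon ortho to a phenylsulfonyl group, exchanging methoxy for carboxy clearly weakens inhibition in this assay: the change gives an at least 5.0-fold higher number from compound 1 to compound 3 (0.70 log units; beyond the scatter). Compound 3 gives > 30000 nM, which is a limit of the assay and not a number. Going by these compounds alone, this is the first evidence that the group at this one place matters for inhibition, as compound 1 and compound 2 differ in more than one place and so cannot isolate the effect of any single position.

Carboxy differs from methoxy in more than one way, including its extra oxygen and its hydrogen-bond donor, and the compounds shown cannot separate these differences; a methyl ester, a primary amide, an amine or a plain hydrogen at this place could help to show which difference counts. The full size of the step also remains open because the result for compound 3 is a limit rather than a number: the limit of > 30000 nM in this assay, at which 1 of the 3 values shown sits.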